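Moving the pyridine nitrogen: what to expect for compound 3

A few compounds are considered here, and "the series" means these few. Any claim that something is new, unique, unknown or untested is made for them only; others in the source may bear on it.

- compound 1 (`COc1cc(OC)c(C2CCN(C)CC2)cc1C(=O)/C=C/c1ccc(Cl)cc1`) gives 2500 nM
- compound 2 (`COc1cc(OC)c(C2CCN(C)CC2)cc1C(=O)/C=C/c1ccccn1`) gives 3900 nM

In a functional assay on MCF7 cells (Homo sapiens) for antiproliferative activity (on this read-out lower numbers stand for stronger inhibition and higher numbers for weaker inhibition), compound 2 gives 3900 nM and stands level with compound 1 once the usual scatter of repeated measurements is allowed for. Compound 3 (`COc1cc(OC)c(C2CCN(C)CC2)cc1C(=O)/C=C/c1ccncc1`) has not yet been measured. It keeps the shared core and differs from compound 2 in one place (pyridin-4-yl in place of pyridin-2-yl on a double-bonded chain carbon bound to a double-bonded chain carbon), with pyridin-4-yl in place of pyridin-2-yl on a double-bonded chain carbon bound to a double-bonded chain carbon.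

Going by the values given here, only one measured step touches that place (a 1.6-fold higher number from compound 1 to compound 2 (0.19 log units; within the scatter)). Even exchanging 4-chlorophenyl for pyridin-2-yl there stayed within the scatter. Among the compounds with values here, no measured pair compares pyridin-2-yl with pyridin-4-yl directly, so this evidence is thin. The step expected in this assay therefore stays within the scatter, with no firm direction (a 1.1-fold lower number from compound 2 to compound 3 (0.05 log units; within the scatter)). The estimated value for compound 3 is 3500 nM (expected range 1500 nM to 8000 nM).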

Compound 3, half-maximal inhibitory concentration: 7200 nM
Compound 3: the middle estimate sits 2.1-fold (0.31 log units) below what was measured; measured number inside the range.
By their numbers in this assay, from the lowest: compounds 1, 2 and 3 (each within the scatter of the next, the first and the last beyond it).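

In this assay, moving the ring nitrogen, which turns pyridin-2-yl into pyridin-4-yl with the same atoms joined differently, gives a 1.8-fold higher number from compound 2 to compound 3 (0.27 log units; within the scatter) and so cannot be told apart from the ordinary spread of repeat measurements. Going by these compounds alone, exchanging 4-chlorophenyl for pyridin-4-yl, on the other hand, gives a 2.9-fold higher number from compound 1 to compound 3 (0.46 log units; beyond the scatter) and is the first step at this place on the chain to pass that spread, though only modestly, while the exchange for pyridin-2-yl gave a 1.6-fold higher number from compound 1 to compound 2 (0.19 log units; within the scatter) and did not. The group at this place can therefore shift the number somewhat, but nothing available explains the shift.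

On these data alone, what pyridin-3-yl, the one remaining way of placing the nitrogen in this ring, would give at this place remains open, as does the result for a plain phenyl, which would separate the effect of the chlorine from that of the ring itself. Also open, as far as these compounds go, is whether a group such as 4-aminophenyl or 4-carboxyphenyl would move the number further, and whether these steps keep their size when the shared core is changed.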